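Two Aryl Groups on a Shared Core, Compared

This account rests on a few compounds, and the source may have more. Where it says the series, first, only, none or still open, it means among the compounds named here.

Compound 1 `Cc1cc(=O)n(-c2ccccc2OC(F)(F)F)nc1C(=O)Nc1ccc(Oc2ncnc3[nH]ccc23)cc1` and compound 2 `Cc1ccc(-n2nc(C(=O)Nc3ccc(Oc4ncnc5[nH]ccc45)c(F)c3)c(C)cc2=O)cc1` share a common core and differ from each other in two places at once. In a functional assay on PC-3 cells (Homo sapiens) for cytotoxicity, read by MTT assay, with a stated time of 72 h (on this read-out higher numbers stand for weaker inhibition and lower numbers for stronger inhibition), compound 1 gives 22500 nM, and compound 2 gives 20400 nM. Compound 2 holds the lower of the two numbers, but its gap to compound 1 lies within the scatter of repeated measurements, so the two values cannot be told apart. Within the data shown here, no pair of measured compounds differs in only one place, so no single-change step is available to guide an expectation.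

Compound 3 `Cc1cc(=O)n(-c2ccccc2OC(F)(F)F)nc1C(=O)Nc1ccc(Oc2ncnc3[nH]ccc23)c(F)c1` has not been measured. It arises from compound 2 by one change: 2-(trifluoromethoxy)phenyl in place of 4-methylphenyl on an aromatic nitrogen. The entering group is already present in compound 1, which in this assay sits within the scatter of compound 2. An essentially flat step is therefore expected, because compound 1 gives 22500 nM while carrying that same group. The expected step is a 1.0-fold higher number from compound 2 to compound 3 (0.01 log units; within the scatter), which amounts to none beyond the scatter. Compound 3 is accordingly estimated at 21000 nM, with a range from 8000 nM to 55000 nM.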

Compound 3, half-maximal inhibitory concentration: > 60000 nM
Compound 3: no number, only a limit (the forecaster's own chance of this, stated with the estimate: 10%); middle value at least 2.8-fold (0.45 log units) away from the limit.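

In this assay compound 3 gives > 60000 nM, which is a limit of the assay and not a number. It still supplies the first single-change steps among these compounds: on the aromatic nitrogen, 2-(trifluoromethoxy)phenyl in place of 4-methylphenyl gives an at least 2.9-fold higher number from compound 2 to compound 3 (0.46 log units; beyond the scatter), and on an aromatic carbon, fluoro in place of hydrogen gives an at least 2.6-fold higher number from compound 1 to compound 3 (0.42 log units; beyond the scatter), which shows that each change counts when the other is already present. Both steps are minimum sizes, and their true sizes stay unknown, because the reading stops at a limit: the limit of > 60000 nM in this assay, at which 1 of the 3 values shown sits.

The fourth combination, 4-methylphenyl with hydrogen in place of fluoro, is not among the compounds shown, and it stays open whether fluoro weakens the number on its own or only alongside 2-(trifluoromethoxy)phenyl. Also open, from the compounds shown here alone, is how the aromatic nitrogen position would respond to a plain phenyl or to a phenyl carrying an amine or a carboxylic acid, and how the fluoro position would respond to chloro.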